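Swapping 4-cyano-3-fluorophenyl for 3-cyano-5-fluorophenyl

The source may report more compounds than this note shows. Statements on the series, on what has been measured and on what is new or still open speak of the compounds shown alone.

Compound 1 (`CC(C)NC(=O)[C@H]1CC[C@@H](n2/c(=N/C(=O)c3ccc(C#N)c(F)c3)[nH]c3ccc(CN4CCC(C(C)(C)O)CC4)cc32)CC1`): 132 mL.min-1.g-1
Compound 2 (`COC(=O)[C@H]1CC[C@@H](n2/c(=N/C(=O)c3ccccc3)[nH]c3ccc(CN4CCCCC4)cc32)CC1`): 85 mL.min-1.g-1

In an in vitro ADME assay on microsomes from liver (Homo sapiens) for metabolic stability (on this read-out higher numbers stand for fast clearance and lower numbers for slow clearance), compound 1 gives 132 mL.min-1.g-1 and compound 2 gives 85 mL.min-1.g-1 as measured numbers. These two values lie within the usual scatter of repeated measurements, so compound 1 cannot be ranked against compound 2 on this read-out.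

Compound 3 (`CC(C)NC(=O)[C@H]1CC[C@@H](n2/c(=N/C(=O)c3cc(F)cc(C#N)c3)[nH]c3ccc(CN4CCC(C(C)(C)O)CC4)cc32)CC1`) has not been measured yet. Compared with compound 1, it has 3-cyano-5-fluorophenyl in place of 4-cyano-3-fluorophenyl on a carbonyl carbon. The two compounds have the same atoms, joined differently, and the rest of the structure is unchanged.

For the measured compounds named here, no measured pair here differs in one place only, so the data give no direct guide to what this change does in this assay for these compounds. The expectation therefore starts from compound 1 at 132 mL.min-1.g-1 and assumes no shift beyond the scatter in either direction. The expected step is a 1.1-fold lower number from compound 1 to compound 3 (0.02 log units; within the scatter) in this estimate, which stays within the scatter. For compound 3 the expected value is 125 mL.min-1.g-1 with an estimated range from 65 mL.min-1.g-1 to 230 mL.min-1.g-1 once it is measured.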

Compound 3, intrinsic clearance in microsomes: 90 mL.min-1.g-1
Beside the measured number, compound 3's estimate is 1.4-fold (0.14 log units) above it; the measured number falls inside the stated range.
By their numbers in this assay, from the lowest: compounds 2, 3 and 1 (each within the scatter of the next).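

For the compounds shown here, replacing 4-cyano-3-fluorophenyl with 3-cyano-5-fluorophenyl on a carbonyl carbon gives, in this assay, a 1.5-fold lower number from compound 1 to compound 3 (0.17 log units; within the scatter) and this is the first pair here that differs in one place only. The two compounds contain the same atoms joined differently, and on this read-out the swap cannot be told apart from the ordinary variation between repeated measurements, so neither compound can be ranked above the other and this arrangement of the nitrile and the fluorine shows no measurable effect. No other measurement shown here bears on this result, so it offers no explanation of the numbers.

As far as these compounds go, whether this position can shift clearance at all stays open, since only these two arrangements of the same groups can be compared directly, and a ring carrying a trifluoromethyl, a methoxy or an amine on the same carbonyl carbon might give a step beyond the scatter. From the compounds shown here alone, it is also open whether the swap would read the same on another background, such as one with a carboxylic acid in place of the isopropyl amide, since compound 2 differs from compound 1 and compound 3 in more than one place and cannot answer this.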